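The source may hold more compounds than are shown below. What is called first, only, known or untested is meant among the compounds shown, and "the series" means these compounds.

Working notes on the series.

Compound 2 `Cc1c(OCCCCOc2ccc(C(=O)O)cc2F)ccc(C(=O)CC(C)C)c1O` gives 57% in an ADME assay (liver) for metabolic stability, with Liver microsome (Rattus norvegicus) as the target, read by LC-MS, using microsomes and NADPH, with stated times of 5 min and 60 min, tested at 4 uM; on this read-out lower numbers stand for a less stable compound and higher numbers for a more stable compound; among the three compounds measured it stands second highest, with compound 1 `Cc1c(OCCCCOc2ccc(C(=O)O)cc2F)ccc(C(=O)CC2CCCC2)c1O` closest to it at 66% and compound 3 `COc1ccc(C(=O)O)cc1OCCCCOc1ccc(C(=O)CC(C)C)c(O)c1C` furthest from it at 5%. For the measured compounds named here, only one single-point step is recorded: a number 9 percentage points lower from compound 1 to compound 2 (within the scatter). Going by the values given here, no single-point step links compound 2 and compound 3; their two numbers merely show that compound 3 sits far lower.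

Compound 4 `Cc1c(OCCCCOc2ccc(F)c(C(=O)O)c2)ccc(C(=O)CC(C)C)c1O` has not yet been measured in this assay. It differs from compound 2 as follows: 3-carboxy-4-fluorophenyl in place of 4-carboxy-2-fluorophenyl on an oxygen on a saturated carbon. Among the compounds with values here, the one recorded step, from compound 1 to compound 2, alters the saturated chain carbon bound to the carbonyl carbon and leaves the aryl ether untouched, so it does not bear on this change. Within the data shown here, no measured pair isolates a rearrangement of the carboxy and fluorine groups on that ring, so the direction of the step cannot be read from the data; the low number of compound 3, whose aryl ring also carries a different substitution pattern, is the only hint that this part of the molecule can matter, and it argues for a wide range.

Compound 4 is therefore expected to give about 45%, within 15% to 72%, the expected step being a number 12 percentage points lower from compound 2 to compound 4 (beyond the scatter).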

Compound 4, percent of the compound remaining: 59%
Estimate against measurement, compound 4: 14 percentage points below; measured number inside the range.
By their numbers in this assay, from the lowest: compound 3; then compounds 2, 4 and 1 (each within the scatter of the next).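

In this assay, for the compounds shown here, the exchange of 4-carboxy-2-fluorophenyl for 3-carboxy-4-fluorophenyl on an oxygen on a saturated carbon gives a number 2 percentage points higher from compound 2 to compound 4 (within the scatter) and this pair is the first to isolate a rearrangement of the carboxy and fluorine groups on that ring. Going by these compounds alone, with the same atoms joined differently, the ring carries either of these two patterns with no difference that stands out from the scatter, so this rearrangement alone does not lead to a number like that of compound 3 at 5% and no step yet links that compound to the others. Nothing measured here gives a reason for this flat result.

Going by these compounds, only these two patterns on the ring are joined by a single-point step, so it stays open whether the read-out holds when a chlorine or a nitrile takes the place of the fluorine, or when an amide or a tetrazole takes the place of the carboxylic acid. Also open, on these data alone, is whether the low number of compound 3 goes with its methoxy group or with the arrangement of its ring, and whether the same flat step would appear with the cyclopentyl of compound 1 in place of isopropyl.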